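Extending the butyl chain of compound 3

The source may report more compounds than this note shows. Statements on the series, on what has been measured and on what is new or still open speak of the compounds shown alone.

Values in a functional assay on NCI-H460 cells (Homo sapiens) for cytotoxicity, read by MTT assay, with a stated time of 72 h; a higher number here means a weaker inhibitor, a lower number a stronger inhibitor:
- compound 1 `CCNC1=CC(=O)C(C(C)(C)C)=CC1=O` gives 64000 nM
- compound 2 `CNC1=CC(=O)C(C(C)(C)C)=CC1=O` gives 63000 nM
- compound 3 `CCCCNC1=CC(=O)C(C(C)(C)C)=CC1=O` gives 36000 nM

Compound 3 stands level with the other two, as a 1.8-fold lower number from compound 2 to compound 3 (0.24 log units; within the scatter) and a 1.8-fold lower number from compound 1 to compound 3 (0.25 log units; within the scatter) show. Compound 4 `CCCCCCCCNC1=CC(=O)C(C(C)(C)C)=CC1=O` has a longer chain on the same core. The change is butyl in place of hydrogen on a saturated chain carbon, four bonds along the chain from an amine nitrogen, on a saturated chain carbon, four bonds along the chain from an amine nitrogen. Those two steps both lengthen the chain, so they bear most directly on this change, and a 1.0-fold lower number from compound 1 to compound 2 (0.01 log units; within the scatter) is another chain change. With so few small steps as a guide, a step of similar size toward a lower number is expected, and it is only a tentative expectation. The estimated step is a 1.8-fold lower number from compound 3 to compound 4 (0.26 log units; within the scatter). For compound 4 the expected value is 20000 nM, within an estimated range from 7000 nM to 50000 nM.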

Compound 4, half-maximal inhibitory concentration: 70000 nM
For compound 4 the middle estimate is 3.5-fold (0.54 log units) below the measured one, and the stated range ends below it.
By their numbers in this assay, from the lowest: compounds 3, 2, 1 and 4 (each within the scatter of the next).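

In this assay, butyl in place of hydrogen, four bonds along the chain from an amine nitrogen, gives a 1.9-fold higher number from compound 3 to compound 4 (0.29 log units; within the scatter) and so does not move compound 4 clear of compound 3. The comparisons with the shorter chains read a 1.1-fold higher number from compound 2 to compound 4 (0.05 log units; within the scatter) and a 1.1-fold higher number from compound 1 to compound 4 (0.04 log units; within the scatter) and also stay level, so across these four compounds chain length from methyl upward separates nothing. No measurement shown here offers an explanation for this.

Still open, as far as these compounds go, is whether a chain ending in a carboxylic acid or an amine, or a benzyl group on the same nitrogen, would give a step beyond the scatter.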